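The source may report more compounds than this note shows. Statements on the series, on what has been measured and on what is new or still open speak of the compounds shown alone.

Working notes on the series.

Compound 1 `C[Se]/C(=N\C(=O)c1ccco1)NC(=O)c1ccco1` and compound 2 `CS/C(=N\C(=O)c1ccco1)NC(=O)c1ccco1` share one core and differ in a single place. Compound 3 `CS/C(=N\C(=O)c1cc(-c2ccccc2)nc2ccccc12)NC(=O)c1cc(-c2ccccc2)nc2ccccc12` rests on a different core; the difference between the core of compound 2 and the core of compound 3 is not broken down here. Compound 4 `C[Se]/C(=N\C(=O)c1cc(-c2ccccc2)nc2ccccc12)NC(=O)c1cc(-c2ccccc2)nc2ccccc12` is the counterpart of compound 3 on that second core and has not yet been measured.

In a functional assay on MCF7 cells (Homo sapiens) for cytotoxicity, read by MTT assay, with a stated time of 72 h (a lower number here means a stronger inhibitor of growth, a higher number a weaker inhibitor of growth), compound 1 gives 30 nM. In this assay compound 2 gives 56100 nM. The change a group of 2 heavy atoms (1 carbon, 1 selenium; no ring) in place of a group of 2 heavy atoms (1 carbon, 1 sulfur; no ring), on a carbon with a double bond to nitrogen produced the step of a 1900-fold lower number from compound 2 to compound 1 (3.27 log units; beyond the scatter). In this assay compound 3 gives 43100 nM; this number and that of compound 2 lie within the scatter of each other, so the two cores cannot be told apart on these two compounds alone.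

Compound 4 arises from compound 3 by a group of 2 heavy atoms (1 carbon, 1 selenium; no ring) in place of a group of 2 heavy atoms (1 carbon, 1 sulfur; no ring), on a carbon with a double bond to nitrogen, the same change as from compound 2 to compound 1, made on the same kind of place. Within the data shown here, only one measured instance of this change exists, so carrying it to the other core is an expectation, not a rule. The expected step is a 1100-fold lower number from compound 3 to compound 4 (3.03 log units; beyond the scatter). Among the measured compounds shown here, this rests on compound 2 because a 1900-fold lower number from compound 2 to compound 1 (3.27 log units; beyond the scatter) is the one measured instance, and on compound 3 as starting point with 43100 nM. Compound 4 is therefore expected to give about 40 nM in this assay, estimated to fall between 5 nM and 600 nM.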

Compound 4, concentration for 50% growth inhibition: 490 nM
Compound 4: the middle estimate sits 12-fold (1.09 log units) below what was measured; measured number inside the range.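

On the core of compound 3, putting the selenium-bearing group in place of methylsulfanyl, on a carbon with a double bond to nitrogen, again lowers the number in this assay. The step is an 88-fold lower number from compound 3 to compound 4 (1.94 log units; beyond the scatter) and it points the same way as the earlier step on the core of compound 1, so the direction of the change carries over between the two cores shown, while its size does not: the same change on two cores in this assay, a 1900-fold lower number (3.27 log units; beyond the scatter) from compound 2 to compound 1 and an 88-fold lower number (1.94 log units; beyond the scatter) from compound 3 to compound 4, 21-fold (1.33 log units) apart, beyond the scatter of two such steps. Two matched pairs show that the change is large on both cores, but they give no rule for its size on any further core and do not tell which part of the cores sets the gap between the two steps.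

The compounds shown leave open whether the large steps are specific to the methyl group on selenium or would persist with a longer chain such as ethyl or benzyl, and how an amine at the same carbon would compare with methylsulfanyl and its selenium counterpart. They also leave open how a third core, for instance one with a carboxylic acid on its rings, would respond to the same change, and whether these steps hold in cells other than those of this assay.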